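Adding a bromine to compound 2

The source may hold more compounds than are shown below. What is called first, only, known or untested is meant among the compounds shown, and "the series" means these compounds.

In a functional assay on MKN-45 cells (Homo sapiens) for antiproliferative activity, read by CellTiter-Glo, with a stated time of 3 days (on this read-out higher numbers stand for weaker inhibition and lower numbers for stronger inhibition), compound 2 (`CC(Oc1c(N)ncc2c(-c3cnn(C4CCNCC4)c3)coc12)c1cc(F)ccc1Cl`) gives 6400 nM and so has the highest number of the three measured compounds. In this assay compound 1 (`CC(Oc1c(N)ncc2c(-c3cnn(C4CCNCC4)c3)coc12)c1c(Cl)cccc1Cl`) gives 2000 nM and compound 3 (`COc1ccc(Cl)c([C@@H](C)Oc2c(N)ncc3c(-c4cnn(C5CCNCC5)c4)coc23)c1Cl`) gives 1600 nM and both lie below compound 2 by more than the scatter. Compound 4 (`CC(Oc1c(N)ncc2c(-c3cnn(C4CCNCC4)c3)coc12)c1c(Br)ccc(F)c1Cl`) is still unmeasured and differs from compound 2 by a group of 9 heavy atoms (6 carbon, 1 fluorine, 1 chlorine, 1 bromine; one six-membered aromatic ring of carbon only) in place of a group of 8 heavy atoms (6 carbon, 1 fluorine, 1 chlorine; one six-membered aromatic ring of carbon only), on a saturated chain carbon bound to an oxygen on an aromatic ring and a saturated chain carbon and thus keeps the fluorine and chlorine while gaining 1 bromine. Among the measured compounds shown here, the one measured step that bears on this is a 3.2-fold higher number from compound 1 to compound 2 (0.51 log units; beyond the scatter) with 2-chloro-5-fluorophenyl in place of 2,6-dichlorophenyl, and it is modest. The ring of compound 4 looks closer to those of compound 1 at 2000 nM and compound 3 at 1600 nM than to that of compound 2, though this rests on very few compounds. A modest move toward stronger inhibition is therefore expected, estimated as a 3.6-fold lower number from compound 2 to compound 4 (0.55 log units; beyond the scatter) in this assay with real uncertainty. The expected value for compound 4 is 1800 nM with a range from 600 nM to 5000 nM.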

Compound 4, half-maximal inhibitory concentration: 510 nM
For compound 4 the middle estimate is 3.5-fold (0.55 log units) above the measured one; measured number below the stated range.
By their numbers in this assay, from the lowest: compound 4; then compounds 3 and 1 (each within the scatter of the next); then compound 2.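

In this assay, among the compounds shown here, one bromine added to the 2-chloro-5-fluorophenyl group on the saturated chain carbon gives a large step, a 13-fold lower number from compound 2 to compound 4 (1.10 log units; beyond the scatter), whereas the only earlier step at this position, a 3.2-fold higher number from compound 1 to compound 2 (0.51 log units; beyond the scatter), was modest. The new group also surpasses the 2,6-dichlorophenyl group, with a 3.9-fold lower number from compound 1 to compound 4 (0.59 log units; beyond the scatter), so this position can support stronger inhibition than the earlier compounds with a directly comparable change had shown. Nothing measured here explains why the bromine has this effect.

The compounds shown leave open whether a methyl, a nitrile or an iodine in place of the bromine would give a similar number. They also leave open how the two mirror forms at the saturated chain carbon of compound 4 compare.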